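Bicyclic ether replacement in the ROCK1 amide series

The source may hold more compounds than are shown below. What is called first, only, known or untested is meant among the compounds shown, and "the series" means these compounds.

Among the measured compounds shown here, compound 2 `COc1ccc(OCC(=O)Nc2cccc(NC(=O)c3ccc(N(C)C)cc3)c2)cc1F` is the only member with a number in an assay on isolated protein for inhibition of Rho-associated protein kinase 1 (Homo sapiens), read by scintillation counting, radiometric assay and 33P incorporation, with a stated time of 40 min, in the presence of a further agent that is not named here (a higher number here means a weaker inhibitor, a lower number a stronger inhibitor), where compound 2 gives 1820 nM. Compound 1 `CN(C)c1ccc(C(=O)Nc2cccc(NC(=O)COc3ccc4c(c3)CCC(=O)N4)c2)cc1` stands at a limit of this assay rather than a number, giving > 10000 nM. For the measured compounds named here, the one measured step, an at least 5.4-fold lower number from compound 1 to compound 2 (0.73 log units; beyond the scatter), rests on (the limit of > 10000 nM in this assay, at which 1 of the 2 values shown sits). Compound 3 `CN(C)c1ccc(C(=O)Nc2cccc(NC(=O)COc3ccc4occc(=O)c4c3)c2)cc1` reverses the sense of that step: a group of 11 heavy atoms (9 carbon, 2 oxygen; one six-membered aromatic ring of carbon only, one six-membered aromatic ring with 1 hetero atom) in place of a group of 9 heavy atoms (7 carbon, 1 oxygen, 1 fluorine; one six-membered aromatic ring of carbon only), on an oxygen on a saturated carbon. The measured step shows that a group of 11 heavy atoms with two rings on this oxygen went with a limit, whereas the smaller group of 9 heavy atoms gave a number; a return to a group of 11 heavy atoms with two rings is therefore expected to move the number upward, a 3.3-fold higher number from compound 2 to compound 3 (0.52 log units; beyond the scatter), with a fair chance that only a limit is reported. Compound 3 is estimated at 6000 nM, with a range of 1500 nM to 20000 nM.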

Compound 3, half-maximal inhibitory concentration: > 10000 nM
Compound 3: only a limit was reported; the forecaster's own chance of this, stated with the estimate: 40%; middle value at least 1.6-fold (0.22 log units) from the limit.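

On the oxygen on a saturated carbon, compound 3 gives only a limit in this assay, so a second two-ring group, this one with a six-membered aromatic ring with 1 hetero atom, joins that of compound 1 in giving no number, and 3-fluoro-4-methoxyphenyl remains the only group shown that gives one. Leaving 3-fluoro-4-methoxyphenyl for this group gives an at least 5.4-fold higher number from compound 2 to compound 3 (0.73 log units; beyond the scatter). The step from compound 1 to compound 3 cannot be read, so the two two-ring groups cannot be ordered, and the reading of this position rests on limits: the limit of > 10000 nM in this assay, at which 2 of the 3 values shown sit.

Still open, from the compounds shown here alone, is whether the second ring or the larger group as a whole goes with the higher number, and what the fluorine and the methoxy each contribute to the value of compound 2. A plain phenyl, a phenyl carrying only the methoxy or only the fluorine, or an aminophenyl on this oxygen would bear on both questions.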